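The source may report more compounds than this note shows. Statements on the series, on what has been measured and on what is new or still open speak of the compounds shown alone.

Measured compounds:
- compound 1, `COc1ccc(C(/C=C/c2ccc(Cl)cc2)=N/O)cc1`: 291000 nM
- compound 2, `COc1ccc(C(/C=C/c2ccc(Br)cc2)=N/O)cc1`: 737000 nM
- compound 3, `COc1ccc(C(/C=C/c2cccs2)=N/O)cc1`: 10600 nM

These three compounds share one core and differ only in the ring that sits on the double-bonded chain. In an ADME assay on cells (Mus musculus, strain Balb/c) for cytotoxicity, read by MTT assay, with a stated time of 48 h (on this read-out higher numbers stand for lower toxicity in this test and lower numbers for higher toxicity in this test), compound 3 gives the lowest of the three numbers, well apart from the other two; compound 1 and compound 2 stand far higher. Among the compounds with values here, the only step that pairs two measured compounds differing in one place is a 2.5-fold higher number from compound 1 to compound 2 (0.40 log units; beyond the scatter), a change on the aromatic ring rather than a change of the ring itself.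

Compound 4, `COc1ccc(C(/C=C/c2ccccc2)=N/O)cc1`, has not been measured in this assay. It differs from compound 3 in one place: phenyl in place of thiophen-2-yl on a double-bonded chain carbon bound to a double-bonded chain carbon. Within the data shown here, no measured step exchanges one ring for another, so the step from compound 1 to compound 2 gives only a loose sense of how much an edit on this ring can move the number. Since the two phenyl-bearing compounds sit far above compound 3, the number for compound 4 is expected to rise, by a step of roughly a 9.4-fold higher number from compound 3 to compound 4 (0.97 log units; beyond the scatter), with wide uncertainty. Compound 4 is expected at about 100000 nM, within a range of 15000 nM to 600000 nM.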

Compound 4, half-maximal cytotoxic concentration: 28600 nM
Compound 4: the middle estimate sits 3.5-fold (0.54 log units) above what was measured, and the stated range covers the measured number.
By their numbers in this assay, from the lowest: compound 3; then compound 4; then compound 1; then compound 2.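

In this assay the exchange of the ring itself moves the number only modestly (a 2.7-fold higher number from compound 3 to compound 4 (0.43 log units; beyond the scatter)), so on this chain carbon phenyl and thiophen-2-yl stand closer together than compound 1 and compound 2 had suggested. The large movements come instead from the group on the aromatic carbon: hydrogen in place of chloro gives a 10-fold lower number from compound 1 to compound 4 (1.01 log units; beyond the scatter) and hydrogen in place of bromo gives a 26-fold lower number from compound 2 to compound 4 (1.41 log units; beyond the scatter), which shows that the high numbers of compound 1 and compound 2 go with those two groups and not with the phenyl ring alone. Nothing at hand explains either the size or the direction of these steps.

Going by these compounds, whether an amine or a carboxylic acid on that aromatic carbon would also raise the number remains open. So does whether chloro or bromo would raise it on thiophen-2-yl as they do on phenyl.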